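The source may report more compounds than this note shows. Statements on the series, on what has been measured and on what is new or still open speak of the compounds shown alone.

Measured so far in a functional assay, with a stated time of 240 min, tested at 100 uM; a higher number here means a stronger effect of the compound at the concentration tested, a lower number a weaker effect:
compound 1 `COc1ccc2nc(-c3cccc(O)c3)c(=O)n(CC(=O)O)c2c1` — 8.5%
compound 2 `COc1ccc2nc(-c3ccc(O)cc3O)c(=O)n(CC(=O)O)c2c1` — 37.2%

Compound 2 stands highest of the two numbers in this assay; the nearest is compound 1, whose value in this assay is given above, and the only measured step, a number 28.7 percentage points higher from compound 1 to compound 2 (beyond the scatter), lies beyond the scatter.

Compound 3 `COc1ccc2nc(-c3cc(O)ccc3O)c(=O)n(CC(=O)O)c2c1` is not yet measured. It differs from compound 2 in one place: 2,5-dihydroxyphenyl in place of 2,4-dihydroxyphenyl on an aromatic carbon. Among the measured compounds shown here, the single measured step bears on this change only indirectly, since it both added a hydroxyl and moved the other, whereas the step from compound 2 to compound 3 keeps the same atoms and only joins them differently. It shows that the placing of hydroxyls on this ring can shift the read-out in this assay by a modest amount, but it gives no direction for moving a hydroxyl from the 4- to the 5-position. The step of a number 12.2 percentage points lower from compound 2 to compound 3 (beyond the scatter) is therefore expected to be small to modest and more likely downward than upward, with a wide range. For compound 3 a value of 25% is estimated, between 8% and 50%.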

Compound 3, a percentage reported as activity, at one concentration (the size of the read-out at that concentration, not a potency): 25.4%
Compound 3: middle estimate off by 0.4 percentage points, on the low side, and the stated range covers the measured number.
By their numbers in this assay, from the lowest: compound 1; then compound 3; then compound 2.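

In this assay the same atoms joined differently give a number 11.8 percentage points lower from compound 2 to compound 3 (beyond the scatter), so the placing of a hydroxyl on this phenyl ring matters by itself, with no change in the count of hydroxyls; the earlier step had changed both count and placing together. The second step isolates a single addition: hydroxy in place of hydrogen on an aromatic carbon gives a number 16.9 percentage points higher from compound 1 to compound 3 (beyond the scatter), and with both dihydroxyphenyl compounds standing above compound 1, none of the three compounds goes against a gain from a second hydroxyl on the 3-hydroxyphenyl ring, though its size depends on where that hydroxyl sits. No measurement at hand explains either step.

Open, on these data alone, is whether the hydroxyls themselves are needed, which a methoxy, an amine or a fluorine in place of either one could test on the 2,4-dihydroxyphenyl and 2,5-dihydroxyphenyl rings. Also open, as far as these compounds go, is whether the order of these ring patterns holds when the carboxymethyl group is replaced by a longer chain ending in a carboxylic acid, or by an amide.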